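The compounds below may be only part of what the source reports. "The series", "measured", "known", "first", "only" and "open" are said of these compounds alone.

In a functional assay on MDA-MB-231 cells (Homo sapiens) for inhibition, read by MTT assay, with a stated time of 48 h (on this read-out lower numbers stand for stronger inhibition and higher numbers for weaker inhibition), compound 1 `COc1cc(-c2nc3cc(/C=C4\SC(=O)NC4=O)ccc3[nH]2)cc(OC)c1OC` gives 6830 nM. Compound 2 `COc1cc(-c2nc3cc(/C=C4\SC(=O)N(CC(=O)N5CCOCC5)C4=O)ccc3[nH]2)cc(OC)c1OC` gives 14900 nM, and compound 3 `COc1cc(-c2nc3cc(/C=C4\SC(=O)N(CC(=O)N5CCCCC5)C4=O)ccc3[nH]2)cc(OC)c1OC` gives 34900 nM, the highest number of the three. The steps of a 2.2-fold higher number from compound 1 to compound 2 (0.34 log units; beyond the scatter) and a 5.1-fold higher number from compound 1 to compound 3 (0.71 log units; beyond the scatter) show that either attachment on the ring nitrogen raised the number, and a 2.3-fold higher number from compound 2 to compound 3 (0.37 log units; beyond the scatter) shows the piperidinyl ring raised it more than the morpholinyl ring. Compound 4 `COc1cc(-c2nc3cc(/C=C4\SC(=O)N(CC(=O)N5CCCC5)C4=O)ccc3[nH]2)cc(OC)c1OC` differs from compound 3 by pyrrolidin-1-yl in place of piperidin-1-yl on a carbonyl carbon. Among the measured compounds shown here, only one measured step exchanges the ring on that carbonyl carbon, and it was modest, so a modest step, most likely downward, or none beyond the scatter, is expected. Compound 4 is estimated at 25000 nM (range 10000 nM to 60000 nM). This expectation amounts to a 1.4-fold lower number from compound 3 to compound 4 (0.14 log units; within the scatter).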

Compound 4, half-maximal inhibitory concentration: 2880 nM
The estimate for compound 4 lay 8.7-fold (0.94 log units) above the measured number; the measured number lies below the stated range.
By their numbers in this assay, from the lowest: compound 4; then compound 1; then compound 2; then compound 3.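

Among the compounds shown here, at this carbonyl carbon, the ring on the amide matters far more than the earlier compounds showed: in this assay, five-membered pyrrolidin-1-yl in place of six-membered piperidin-1-yl gives a 12-fold lower number from compound 3 to compound 4 (1.08 log units; beyond the scatter) and in place of morpholin-4-yl gives a 5.2-fold lower number from compound 2 to compound 4 (0.71 log units; beyond the scatter). The attachment on the ring nitrogen can also lower the number, since ((pyrrolidin-1-yl)carbonyl)methyl in place of hydrogen gives a 2.4-fold lower number from compound 1 to compound 4 (0.38 log units; beyond the scatter). No evidence here explains these steps. The compounds shown leave open whether the smaller azetidin-1-yl ring would lower the number further. They also leave open how an open-chain diethylamino group on that carbonyl carbon would compare.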